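The source may hold more compounds than are shown below. What is called first, only, known or untested is meant among the compounds shown, and "the series" means these compounds.

Measured compounds:
- compound 1 `CCCc1ccc(C2CC(c3ccc(O)cc3)=NN2C(=O)c2cccnc2)cc1`: 41600 nM in an ADME assay on HepG2 cells (Homo sapiens) for cytotoxicity, read by MTT assay, with a stated time of 7 days; on this read-out higher numbers stand for weaker inhibition and lower numbers for stronger inhibition
- compound 2 `O=C(c1cccnc1)N1N=C(c2ccc(O)cc2)CC1c1ccc([N+](=O)[O-])cc1`: 18600 nM in this assay

Among the compounds with values here, compound 2 holds the lower of the two numbers in this assay; the single measured step, a 2.2-fold lower number from compound 1 to compound 2 (0.35 log units; beyond the scatter), separates it from compound 1. Compound 3 `CC(C)c1ccccc1C1CC(c2ccc(O)cc2)=NN1C(=O)c1cccnc1` is not yet measured. It differs from compound 2 in 2-isopropylphenyl in place of 4-nitrophenyl on a saturated ring carbon. Within the data shown here, the one step on record bears on this change: a 2.2-fold lower number from compound 1 to compound 2 (0.35 log units; beyond the scatter) shows that nitro in place of propyl on the phenyl ring lowered the number, and compound 3 moves the other way, from nitro back to an alkyl substituent, here isopropyl on a 2-isopropylphenyl. Whether the altered placement of the substituent changes anything cannot be judged from two compounds. A modest rise in the number is therefore expected, a 1.9-fold higher number from compound 2 to compound 3 (0.27 log units; within the scatter), with wide uncertainty. Compound 3 is estimated at 35000 nM, within a range of 14000 nM to 90000 nM.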

Compound 3, half-maximal inhibitory concentration: 49700 nM
Compound 3: the middle estimate sits 1.4-fold (0.15 log units) below what was measured; low and high end bracket the measured number.
By their numbers in this assay, from the lowest: compound 2; then compounds 1 and 3 (each within the scatter of the next).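

In this assay, the substituted phenyl on the saturated ring carbon has now been changed twice from 4-nitrophenyl to an alkyl-bearing phenyl, and the second case gives a 2.7-fold higher number from compound 2 to compound 3 (0.43 log units; beyond the scatter), so the lower number of compound 2 stands against both compound 1 and compound 3 rather than against a single partner. The two alkyl-bearing groups cannot be told apart, with a 1.2-fold higher number from compound 1 to compound 3 (0.08 log units; within the scatter), so 2-isopropylphenyl and 4-propylphenyl read alike on this read-out. Nothing on record accounts for either step.

Whether the lower number is particular to the nitro group stays open, since no other non-alkyl group, such as an amine or a carboxylic acid on that phenyl ring, appears among these compounds. As far as these compounds go, the 4-hydroxyphenyl and (pyridin-3-yl)carbonyl groups are shared by all three compounds, so their contribution also remains open.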